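Changing the amide group of compound 3

The source may report more compounds than this note shows. Statements on the series, on what has been measured and on what is new or still open speak of the compounds shown alone.

Measured so far in an ADME assay on the whole organism (Rattus norvegicus, strain Wistar Han) for pharmacokinetics, read by LC-MS, with a stated time of 7 h, at a dose of 3 mg/kg by the oral route (a lower number here means that a smaller share of the oral dose reaches the circulation, a higher number that a larger share of the oral dose reaches the circulation), are three compounds.
- compound 1 `CNC(=O)c1cc(C(=O)N[C@H]2CC[C@H](O)CC2)c([C@@H](C)c2cccc(Cl)c2)o1` with 37%
- compound 2 `CNC(=O)c1cc(C(=O)N[C@H]2[C@@H]3COC[C@@H]32)c([C@@H](C)c2ccccc2)o1` with 100%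
- compound 3 `CNC(=O)c1cc(C(=O)N[C@H]2[C@@H]3C[C@@H](O)C[C@@H]32)c([C@@H](C)c2ccccc2)o1` with 67%

Compound 3 stands second highest of these three numbers, beyond the scatter from both compound 1 and compound 2. Compound 4 `CNC(=O)c1cc(C(=O)N[C@H]2CC[C@H](O)CC2)c([C@@H](C)c2ccccc2)o1` keeps the core of compound 3 and changes only the group on an amide-type nitrogen (a group of 7 heavy atoms (6 carbon, 1 oxygen; one six-membered non-aromatic ring of carbon only) in place of a group of 7 heavy atoms (6 carbon, 1 oxygen; one three-membered non-aromatic ring of carbon only, one five-membered non-aromatic ring of carbon only), on an amide-type nitrogen). The group that enters is 4-hydroxycyclohexyl.

Among the compounds with values here, one measured step touches this same place, a number 33 percentage points lower from compound 2 to compound 3 (beyond the scatter), and it is large. A change here alone can therefore move the oral share substantially. Compound 1 already carries 4-hydroxycyclohexyl and gives 37%, but its core also holds a chlorine that compound 4 lacks, and no measurement separates the two differences. This points downward, with an uncertain size. The expected change is a clear fall, a number 22 percentage points lower from compound 3 to compound 4 (beyond the scatter), in this assay. For compound 4 the estimate is 45%, with an expected range from 25% to 70%.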

Compound 4, oral bioavailability: 72%
Compound 4: the middle estimate sits 27 percentage points below what was measured; the whole stated range lies below it.
By their numbers in this assay, from the lowest: compound 1; then compounds 3 and 4 (each within the scatter of the next); then compound 2.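

In this assay the swap from the two-ring group to 4-hydroxycyclohexyl on the amide-type nitrogen gives a number 5 percentage points higher from compound 3 to compound 4 (within the scatter) and so leaves these two groups indistinguishable, even though their ring shapes differ. Against the group with an oxygen in its ring, 4-hydroxycyclohexyl gives a number 28 percentage points lower from compound 2 to compound 4 (beyond the scatter) and so, like the two-ring group, stands clearly apart from it. With 4-hydroxycyclohexyl held fixed, hydrogen in place of chloro on an aromatic carbon gives a number 35 percentage points higher from compound 1 to compound 4 (beyond the scatter) and shows that the gap between these two compounds lies with the chloro group, not with the amide group.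

No measurement at hand explains any of these steps. On these data alone, it also remains open how an amine or a carboxylic acid in place of the hydroxyl on the cyclohexyl ring would fare, and whether the chloro step repeats with the other amide groups.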